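A few compounds are considered here, and "the series" means these few. Any claim that something is new, unique, unknown or untested is made for them only; others in the source may bear on it.

Working notes on the series. Compound 1 `COc1nc(-c2cc3ccccc3o2)cc(-c2ccccc2)c1C#N` gives 232000 nM in a functional assay on aorta (strain Wistar) for inhibition, with Thoracic aorta (Rattus norvegicus) as the target; on this read-out lower numbers stand for stronger inhibition and higher numbers for weaker inhibition. Compound 2 `CCOc1nc(-c2cc3ccccc3o2)cc(-c2ccccc2)c1C#N` gives 310000 nM in this assay, and the step of a 1.3-fold higher number from compound 1 to compound 2 (0.13 log units; within the scatter) stays within the scatter. Compound 3 `COc1nc(-c2cc3ccccc3o2)cc(-c2cccc3ccccc23)c1C#N` gives 359000 nM in this assay. Where compound 3 stands: its number lies within the scatter of compound 2 and likewise within the scatter of compound 1, so on the numbers shown the three measured compounds cannot be told apart.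

Compound 4 `CCOc1nc(-c2cc3ccccc3o2)cc(-c2cccc3ccccc23)c1C#N` has not been measured. Relative to compound 3 the change is methyl in place of hydrogen on a saturated chain carbon bound to an oxygen on an aromatic ring. Among the compounds with values here, one measured step bears on this change, the step of a 1.3-fold higher number from compound 1 to compound 2 (0.13 log units; within the scatter), which is the same swap on the pair of compound 1 and compound 2; there the number moved only within the scatter. Within the data shown here, nothing among the measured compounds indicates that the swap on compound 3 would behave otherwise. The expected step is therefore a 1.2-fold higher number from compound 3 to compound 4 (0.07 log units; within the scatter) in this assay, meaning no change beyond the scatter in either direction. Compound 4 is expected at 420000 nM in this assay, with a range from 200000 nM to 850000 nM.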

Compound 4, half-maximal inhibitory concentration: 344000 nM
Beside the measured number, compound 4's estimate is 1.2-fold (0.09 log units) above it, within the range that was stated.
By their numbers in this assay, from the lowest: compounds 1, 2, 4 and 3 (each within the scatter of the next).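

Methoxy to ethoxy can now be read on a second core, and with naphthalen-1-yl in place of phenyl the swap again leaves the number inside the scatter in this assay: the same change on two cores in this assay, a 1.3-fold higher number (0.13 log units; within the scatter) from compound 1 to compound 2 and a 1.0-fold lower number (0.02 log units; within the scatter) from compound 3 to compound 4, 1.4-fold (0.14 log units) apart, within the scatter of two such steps The other change, naphthalen-1-yl in place of phenyl on an aromatic carbon, now has a step of its own on the ethoxy side, a 1.1-fold higher number from compound 2 to compound 4 (0.05 log units; within the scatter), and it too stays within the scatter. On the second core the methyl step reads a 1.0-fold lower number from compound 3 to compound 4 (0.02 log units; within the scatter), so across these four compounds neither change moves the number beyond the scatter, and the size of the methyl step shows no dependence on which of the two aromatic groups the core carries.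

Going by these compounds, how a longer chain such as butoxy, or a chain ending in an amine or a carboxylic acid, would read in this assay stays open. Also open, on these data alone, is whether any change at this position or on the shared core, for instance a carboxylic acid in place of the nitrile, would move the number beyond the scatter at all.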